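The source may report more compounds than this note shows. Statements on the series, on what has been measured and on what is new or still open speak of the compounds shown alone.

Measured in a functional assay on the whole organism for inhibition, with Rattus norvegicus as the target; a higher number here means that more compound is needed for the effect, a lower number that less compound is needed:

Compound 1 `CN(C)C(=O)n1cc(C(=O)c2ccn3c2CSC3c2cccnc2)c2ccc(OCc3ccccc3)cc21` gives 3.3 mg/kg.
Compound 2 `CN(C)C(=O)n1cc(C(=O)c2ccn3c2CSC3c2cccnc2)c2ccc(-c3ccccc3)cc21` gives 0.06 mg/kg.
Compound 3 `NC(=O)n1cc(C(=O)c2ccn3c2CSC3c2cccnc2)c2ccc(-c3ccc(F)cc3)cc21` gives 0.06 mg/kg.

Compound 3 sits at the low end of these numbers, level with compound 2 at the digits shown, while compound 1 needs far more compound. For the measured compounds named here, the one step between compounds that differ in a single place runs a 55-fold lower number from compound 1 to compound 2 (1.74 log units; beyond the scatter); it concerns the group on the aromatic carbon, not the aromatic nitrogen, so it says nothing direct about the change considered here. Compounds 2 and 3 differ in two places at once, among them the group on the aromatic nitrogen, and their values are the same at the digits shown.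

Compound 4 `CN(C)C(=O)Cn1cc(C(=O)c2ccn3c2CSC3c2cccnc2)c2ccc(-c3ccc(F)cc3)cc21` differs from compound 3 by (dimethylcarbamoyl)methyl in place of carbamoyl on an aromatic nitrogen. Going by the values given here, no measured step covers this exchange, so the expectation rests on the unchanged values of compound 2 and compound 3 and carries a wide range. A small step is expected, a 1.7-fold higher number from compound 3 to compound 4 (0.22 log units; within the scatter), likely within the scatter. Compound 4 is therefore estimated at 0.1 mg/kg, with a range from 0.03 mg/kg to 0.5 mg/kg.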

Compound 4, dose for half-maximal effect: 0.12 mg/kg
The estimate for compound 4 lay 1.2-fold (0.08 log units) below the measured number; measured number inside the range.
By their numbers in this assay, from the lowest: compounds 2, 3 and 4 (each within the scatter of the next); then compound 1.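

In this assay, this aromatic nitrogen accepts a clearly different group: replacing carbamoyl with (dimethylcarbamoyl)methyl gives a 2.0-fold higher number from compound 3 to compound 4 (0.30 log units; within the scatter) and leaves the two compounds indistinguishable. The entering group has 6 heavy atoms against 3 and 0 hydrogen-bond donors against 1, so for this pair neither the smaller carbamoyl nor its donor is needed to stay in this range of doses. Nothing measured here explains why the exchange is tolerated.

Still open, from the compounds shown here alone, is whether an amine, a carboxylic acid or a longer chain on this aromatic nitrogen would stay in the same range. Also open, going by these compounds, is whether the exchange would read the same with the benzyloxy group of compound 1 in place of the aromatic group on the core of compound 3.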